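A few compounds are considered here, and "the series" means these few. Any claim that something is new, unique, unknown or untested is made for them only; others in the source may bear on it.

Compound 2 `CCC(C)C(NC(=O)NO)C(=O)NC(c1ccccc1)c1ccccc1` gives the lowest of the two numbers in a functional assay on HEp-2 cells (Homo sapiens) for inhibition (on this read-out higher numbers stand for weaker inhibition and lower numbers for stronger inhibition), namely 35800 nM. Its nearest neighbour is compound 3 `CCC(C)C(NC(=O)n1nnc2ccccc21)C(=O)NC(c1ccccc1)c1ccccc1`, which in this assay gives 55300 nM; the step is a 1.5-fold higher number from compound 2 to compound 3 (0.19 log units; within the scatter), and it falls on a carbonyl carbon, not on the amide side. Compound 1 `CC(C)C(NC(=O)NO)C(=O)NC1CCCCC1` in this assay reaches only a limit, (the limit of > 100000 nM in this assay, at which 1 of the 3 values shown sits), recorded as > 100000 nM. Compound 4 `CCC(C)C(NC(=O)NO)C(=O)NCc1ccccc1` carries hydrogen in place of phenyl on a saturated chain carbon bound to an amide-type nitrogen and an aromatic carbon. Among the compounds with values here, no measured step touches this position, so no measured guide exists for its size. A weaker number is nonetheless expected, and from compound 2 to compound 4 a step of a 2.2-fold higher number from compound 2 to compound 4 (0.35 log units; beyond the scatter) is estimated. Compound 4 is expected near 80000 nM, between 30000 nM and 250000 nM.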

Compound 4, half-maximal inhibitory concentration: > 100000 nM
Compound 4: only a limit was reported; the forecaster's own chance of this, stated with the estimate: 40%; middle value at least 1.2-fold (0.09 log units) from the limit.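

In this assay, within the data shown here, hydrogen in place of phenyl on a saturated chain carbon bound to an amide-type nitrogen and an aromatic carbon is the first change on the amide side with a readable size (an at least 2.7-fold higher number from compound 2 to compound 4 (0.44 log units; beyond the scatter)), and the step lies beyond the scatter. The second phenyl of compound 2 therefore counts for more here than the carbonyl-carbon change, whose step stayed within the scatter. Compound 4 reaches only a limit, so this size is a minimum: the limit of > 100000 nM in this assay, at which 2 of the 4 values shown sit.

The compounds shown leave open whether phenyl itself is needed on this carbon, or whether a methyl group or a pyridine ring there would hold the number of compound 2.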